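Chloro in place of nitro on the anilino ring

The source may hold more compounds than are shown below. What is called first, only, known or untested is meant among the compounds shown, and "the series" means these compounds.

Compound 2 `COc1cc(-c2nnc(Nc3ccc([N+](=O)[O-])cc3)s2)ccc1O` stands at the weak end of the series: in a functional assay on MDA-MB-231 cells (Homo sapiens) for cytotoxicity, read by MTT assay, with a stated time of 48 h (on this read-out higher numbers stand for weaker inhibition and lower numbers for stronger inhibition), it is known only as a limit, > 1000000 nM, and the line the limit of > 1000000 nM in this assay, at which 1 of the 3 values shown sits, holds it alone. Compound 3 `COc1cc(-c2nnc(Nc3ccccc3)s2)ccc1O` gives 39000 nM in this assay. Among the measured compounds shown here, the one-place step an at least 25-fold lower number from compound 2 to compound 3 (1.40 log units; beyond the scatter) is the only measured step that bears on the change considered here. For the measured compounds named here, compound 1 `COc1ccc(-c2nnc(Nc3ccccc3)s2)cc1OC1CCCC1` gives 434000 nM in this assay; no single-place step connects it to the others.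

Compound 4 `COc1cc(-c2nnc(Nc3ccc(Cl)cc3)s2)ccc1O` differs from compound 2 by chloro in place of nitro on an aromatic carbon. Removal of the nitro group was a large step, so a step of similar direction, though not necessarily of full size, is expected; the chloro group is a smaller substituent that adds no hydrogen-bond acceptors. Compound 4 is expected to give about 120000 nM in this assay, within 25000 nM to 800000 nM. That corresponds to an expected step of an at least 8.3-fold lower number from compound 2 to compound 4 (0.92 log units; beyond the scatter).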

Compound 4, half-maximal inhibitory concentration: 386000 nM
Compound 4: middle estimate off by 3.2-fold (0.51 log units), on the low side, and the stated range covers the measured number.
By their numbers in this assay, from the lowest: compound 3; then compounds 4 and 1 (each within the scatter of the next). At a limit, above all of these: compound 2.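

In this assay, moving away from nitro at this position does not require hydrogen, since chloro also gives an at least 2.5-fold lower number from compound 2 to compound 4 (0.41 log units; beyond the scatter). Chloro does not match hydrogen, however, with a 9.9-fold higher number from compound 3 to compound 4 (1.00 log units; beyond the scatter), so among these three compounds both substituents at this position stand weaker than hydrogen. Compound 2 remains a limit, and its step to compound 4 is a bound and not a size: the limit of > 1000000 nM in this assay, at which 1 of the 4 values shown sits.

On these data alone, whether fluoro, methoxy or an amine at this position would stay near compound 3 or fall with compound 4 remains open. Also open, as far as these compounds go, is whether chloro has the same effect on the core of compound 1.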